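Compound 2 to compound 3: a carbonyl substituent swap

The source may report more compounds than this note shows. Statements on the series, on what has been measured and on what is new or still open speak of the compounds shown alone.

In a functional assay on U-373MG ATCC cells (Homo sapiens) for inhibition, read by MTT assay, with a stated time of 72 h (on this read-out lower numbers stand for stronger inhibition and higher numbers for weaker inhibition), compound 2 `CC(=O)NC1CC(C)(C)Oc2ccc(Cl)cc21` reads > 100000 nM. This value is a limit of the assay and not a number.

For the measured compounds named here, the only numerical reading so far comes from compound 1 `CC1(C)CC(NC(=O)Nc2cccc(Cl)c2)c2cc(F)ccc2O1`, which gives 39000 nM in this assay.

Compound 3 `CC1(C)CC(NC(=O)Nc2cccc(Cl)c2)c2cc(Cl)ccc2O1` departs from compound 2 as follows: (3-chlorophenyl)amino in place of methyl on a carbonyl carbon. In words, (3-chlorophenyl)amino stands in place of methyl on a carbonyl carbon, and compound 1 carries the same group in the same place.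

Going by the values given here, no measured pair isolates this change, so the size of the step is poorly defined. In this assay, a step toward lower numbers, beyond the scatter, is expected. This expectation rests on compound 1, which carries that group and reads 39000 nM. The expected step is modest in absolute terms, and a reading close to that of compound 1 seems most likely.

The estimated step is an at least 3.3-fold lower number from compound 2 to compound 3 (0.52 log units; beyond the scatter).

Compound 3 is estimated at 30000 nM, with an expected range from 12000 nM to 80000 nM.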

Compound 3, half-maximal inhibitory concentration: 21000 nM
For compound 3 the middle estimate is 1.4-fold (0.15 log units) above the measured one, within the range that was stated.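

In this assay compound 2 reads > 100000 nM, which is a limit of the assay and not a number. For the compounds shown here, on the carbonyl carbon, (3-chlorophenyl)amino in place of methyl now has a direct pair, which gives an at least 4.7-fold lower number from compound 2 to compound 3 (0.67 log units; beyond the scatter), and this step can be stated only as a bound because one end of the pair is that limit: the limit of > 100000 nM in this assay, at which 1 of the 3 values shown sits. On an aromatic carbon of the shared core, chloro in place of fluoro gives a 1.9-fold lower number from compound 1 to compound 3 (0.27 log units; within the scatter), so this pair does not separate the two halogens in this read-out, and the group on the carbonyl carbon is the only one of the two changes with a step beyond the scatter.

The pair from compound 2 to compound 3 changes the whole group at once, so it cannot assign the step to the nitrogen, the aromatic ring or the chlorine; plain phenylamino, methylamino or a benzyl group on the same carbonyl carbon would begin to divide it. On the aromatic carbon, only chloro and fluoro are shown, which leaves open how a larger or different group, such as bromo, methoxy or nitrile, would read.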